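Iodo for isopropyl in a urea series: an expected shift

This account rests on a few compounds, and the source may have more. Where it says the series, first, only, none or still open, it means among the compounds named here.

Within the data shown here, compound 1 `CC(C)c1cccc(NC(=O)N[C@H](C)c2ccccc2)c1` gives 61% in an ADME assay on the whole organism with Oryza sativa as the target, tested at 1 uM (on this read-out lower numbers stand for a stronger effect and higher numbers for a weaker effect at the one concentration tested), the lowest of the three numbers known. Its configurational partner compound 2 `CC(C)c1cccc(NC(=O)N[C@@H](C)c2ccccc2)c1` gives 84%, a change of a number 23 percentage points higher from compound 1 to compound 2 (beyond the scatter), which the data relate to the fact that compounds 1 and 2 differ only in the configuration as drawn. Among the measured compounds shown here, compound 3 `C[C@H](NC(=O)Nc1ccccc1I)c1ccccc1` gives 100%; no single step joins it to compound 1. Compound 4 `C[C@@H](NC(=O)Nc1cccc(I)c1)c1ccccc1` differs from compound 1 by iodo in place of isopropyl on an aromatic carbon. For the measured compounds named here, no measured step covers this exchange, and the only measured step concerns configuration, so the expectation rests on the spread of the three numbers. A modest upward step is expected, a number 14 percentage points higher from compound 1 to compound 4 (beyond the scatter), and compound 4 is estimated at 75%, between 50% and 100%.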

Compound 4, a percentage reported as activity, at one concentration (the size of the read-out at that concentration, not a potency): 75%
Compound 4: middle estimate and measured number agree at the digits printed; low and high end bracket the measured number.
By their numbers in this assay, from the lowest: compound 1; then compounds 4 and 2 (each within the scatter of the next); then compound 3.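

Iodo in place of isopropyl, on an aromatic carbon meta to a large group, gives in this assay a number 14 percentage points higher from compound 1 to compound 4 (beyond the scatter) as the first measured exchange of a group in this series. This position therefore responds to the group it carries, and this change moves the read-out towards a weaker effect at the one concentration tested. Nothing shown gives a reason for this step.

The compounds shown leave open how a longer chain, an amine or a carboxylic acid on this aromatic carbon would read out.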